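This account rests on a few compounds, and the source may have more. Where it says the series, first, only, none or still open, it means among the compounds named here.

Measured in an ADME assay on HepG2 2.2.15 cells (Homo sapiens) for cytotoxicity, read by CCK-8 assay, with a stated time of 8 days; a higher number here means that more compound is tolerated, a lower number that less compound is tolerated:
- compound 1 `COc1ccc(-c2cc(NC(=O)c3ccccc3O)c[nH]c2=O)cc1`: > 100000 nM
- compound 2 `COc1ccc(-c2cc(NC(=O)c3ccc(OC)cc3O)c[nH]c2=O)cc1`: 49900 nM

Compound 1 gives no exact number and stands only at a limit, (the limit of > 100000 nM in this assay, at which 1 of the 2 values shown sits). Compound 3 `Cc1cccc(-c2cc(NC(=O)c3ccccc3O)c[nH]c2=O)c1` has not yet been measured. It departs from compound 1 by one change, 3-methylphenyl in place of 4-methoxyphenyl on an aromatic carbon.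

Among the compounds with values here, no measured step alters that aryl group. Within the data shown here, the only step available is an at least 2.0-fold lower number from compound 1 to compound 2 (0.30 log units; that floor lies within the scatter), which is methoxy in place of hydrogen on an aromatic carbon, at another place in the molecule. It therefore bears on the change only indirectly, and its floor gives no firm size. No step beyond the scatter is expected in this assay. If one does appear, a lower number is the likelier direction, since the only exact reading so far is compound 2 at 49900 nM.

Compound 3 is estimated at 70000 nM. The expected range for this compound runs from 25000 nM to 100000 nM. The estimate means an expected at least 1.4-fold lower number from compound 1 to compound 3 (0.15 log units; that floor lies within the scatter).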

Compound 3, half-maximal cytotoxic concentration: 98800 nM
Compound 3: the middle estimate sits 1.4-fold (0.15 log units) below what was measured; measured number inside the range.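

In this assay, within the data shown here, a change to the aryl group on the shared core can now be read for the first time, and exchanging 4-methoxyphenyl for 3-methylphenyl gives an at least 1.0-fold lower number from compound 1 to compound 3 (0.00 log units; that floor lies within the scatter). Compound 3 does give an exact number, 98800 nM, which shows that this aryl position can carry 3-methylphenyl, a group without the oxygen of 4-methoxyphenyl, with no step beyond the scatter. The size of this step stays open, since the reading for compound 1 is a limit of the assay and not a number: the limit of > 100000 nM in this assay, at which 1 of the 3 values shown sits.

Among these compounds, whether a different group on this aryl ring, such as an amine or a carboxylic acid, would bring a step beyond the scatter remains open, as this single change covers only two aryl groups. As far as these compounds go, it is also unknown how 3-methylphenyl would behave in combination with the added methoxy group that distinguishes compound 2 from compound 1, and the exact value of compound 1 remains unknown.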